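The compounds below may be only part of what the source reports. "The series", "measured", "known", "first", "only" and "open" are said of these compounds alone.

Measured compounds:
- compound 1, `C=C1C(=O)O[C@H]2C[C@@H](C)C(CCC(C)O)=CC[C@H]12`, gives 870 nM
- compound 2, `C=C1C(=O)O[C@@H]2C[C@H](C)C(CCC(C)OC(C)=O)=CC[C@H]12`, gives 810 nM

Both measurements come from a functional assay on RAW264.7 cells (Mus musculus) for inhibition, read by Griess assay, with stated times of 30 min and 24 h; a lower number here means a stronger inhibitor, a higher number a weaker inhibitor. Compound 2 gives the lowest of the two numbers, but the number for compound 1 lies within the usual scatter of it, so the two compounds cannot be ranked against each other on these data.

The next compound to consider is compound 3, `C=C1C(=O)O[C@@H]2C[C@H](C)C(CCC(C)O)=CC[C@H]12`, which has not yet been measured in this assay. Its relation to compound 2 is a single change: hydrogen in place of acetyl on an oxygen on a saturated carbon. The acetyl group on the oxygen is gone and a bare hydroxy group remains, so the chain ends as 2-hydroxypropyl instead of 2-acetoxypropyl.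

Going by the values given here, no measured pair in this set differs only by this change, so the size of the step has to be judged from what is at hand. Among the compounds with values here, the only comparison that touches an acetoxy against a hydroxy is between compound 1 and compound 2, whose numbers sit within the scatter of each other. On that basis the step from compound 2 to compound 3 is expected to be small, with no direction beyond the scatter, as a 1.1-fold higher number from compound 2 to compound 3 (0.05 log units; within the scatter). Compound 3 is therefore estimated at 900 nM, with a plausible range from 400 nM to 2000 nM.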

Compound 3, half-maximal inhibitory concentration: 5480 nM
For compound 3 the middle estimate is 6.1-fold (0.78 log units) below the measured one; measured number outside the range, above it.
By their numbers in this assay, from the lowest: compounds 2 and 1 (each within the scatter of the next); then compound 3.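

Taking the acetyl off this oxygen, with everything else in the structure unchanged, gives a 6.8-fold higher number from compound 2 to compound 3 (0.83 log units; beyond the scatter) in this assay, so the change from 2-acetoxypropyl to 2-hydroxypropyl is not a neutral one here. The configuration of the core counts as well: with the same atoms and bonds and the 2-hydroxypropyl chain in both compounds, the opposite drawing at two stereocentres on saturated ring carbons gives a 6.3-fold higher number from compound 1 to compound 3 (0.80 log units; beyond the scatter). That second step needs some caution, since the two drawings are not equally defined where they differ: the fact that one of compounds 1 and 3 is drawn with a defined configuration and the other without, at the place where they differ

Going by these compounds, it remains open whether removing the acetyl would have a similar effect in the configuration of compound 1, which appears here only with the free hydroxy group. Also unanswered is how other groups on this oxygen would compare with the acetyl of compound 2 and the hydrogen of compound 3, for example a longer butanoyl ester or a methyl ether, or how an amine would behave in place of the oxygen itself.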